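Lengthening the Side Chain of Compound 1

The source may report more compounds than this note shows. Statements on the series, on what has been measured and on what is new or still open speak of the compounds shown alone.

Compound 1 `C=CCOc1cc(/C=C\c2cc(OC)c(OC)c(OC)c2)ccc1OC` was tested in a functional assay on MCF7 cells (Homo sapiens) for inhibition, read by MTT assay, with a stated time of 3 days (on this read-out higher numbers stand for weaker inhibition and lower numbers for stronger inhibition), where compound 1 gives 12000 nM. Of the two numbers at hand this is the highest, so compound 1 is the weakest inhibitor measured here. Compound 2 `C/C=C/COc1cc(/C=C\c2cc(OC)c(OC)c(OC)c2)ccc1OC` differs from compound 1 in one place, and in this assay compound 2 gives 5400 nM. The step of a 2.2-fold lower number from compound 1 to compound 2 (0.35 log units; beyond the scatter) shows that a slightly longer group at the same place brought a lower number.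

Compound 3 `COc1ccc(/C=C/CCCOc2cc(/C=C\c3cc(OC)c(OC)c(OC)c3)ccc2OC)cc1` carries a far larger change at that place: 4-(4-methoxyphenyl)but-3-en-1-yl in place of vinyl on a saturated chain carbon bound to an oxygen on an aromatic ring. Within the data shown here, the only measured step, a 2.2-fold lower number from compound 1 to compound 2 (0.35 log units; beyond the scatter), points toward a lower number with a longer group, but it is small and the new group is much bigger, so it offers weak guidance. A modest lowering is expected, a 2.0-fold lower number from compound 1 to compound 3 (0.30 log units; within the scatter), and compound 3 is estimated at 6000 nM, likely between 1500 nM and 25000 nM.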

Compound 3, half-maximal inhibitory concentration: 16000 nM
Compound 3: middle estimate off by 2.7-fold (0.43 log units), on the low side, within the range that was stated.
By their numbers in this assay, from the lowest: compound 2; then compounds 1 and 3 (each within the scatter of the next).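

At this place on a saturated chain carbon bound to an oxygen on an aromatic ring, the far larger 4-(4-methoxyphenyl)but-3-en-1-yl group, with its added aromatic ring, leaves this assay within the scatter of the vinyl compound (a 1.3-fold higher number from compound 1 to compound 3 (0.12 log units; within the scatter)). The same group gives a clearly weaker result than prop-1-en-1-yl (a 3.0-fold higher number from compound 2 to compound 3 (0.47 log units; beyond the scatter)), so compound 3 goes against the idea that a longer group here always means a lower number, and compound 2 remains the strongest of the three. No measurement explains why the trend fails to continue.

The compounds shown leave open where between prop-1-en-1-yl and the much larger group the number starts to rise. They also leave open whether a plain butyl chain, or one ending in an amine, would behave more like compound 2 or compound 3.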